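This account rests on a few compounds, and the source may have more. Where it says the series, first, only, none or still open, it means among the compounds named here.

In a functional assay on KB cells (Homo sapiens) for antiproliferative activity, read by colorimetric assay and MTT assay (a lower number here means a stronger inhibitor, a higher number a weaker inhibitor), compound 3 (`Nc1ccc(S(=O)(=O)Nc2cccc3c(Cl)c[nH]c23)cc1`) gives 10 ug/mL, which lies within the scatter of compound 1 (`O=[N+]([O-])c1ccc(S(=O)(=O)Nc2cccc3c(Cl)c[nH]c23)cc1`) at 14 ug/mL and of compound 2 (`N#Cc1ccc(S(=O)(=O)Nc2ccc(Cl)c3c(Cl)c[nH]c23)cc1`) at 13 ug/mL. Compound 4 (`Nc1ccc(S(=O)(=O)Nc2ccc(Cl)c3c(Cl)c[nH]c23)cc1`) differs from compound 3 by a single change: chloro in place of hydrogen on an aromatic carbon. Within the data shown here, the only measured step, a 1.4-fold lower number from compound 1 to compound 3 (0.15 log units; within the scatter), puts amino in place of nitro and stays within the scatter. Among the measured compounds shown here, no measured step tests the chloro alone. Compound 2 carries the same chloro together with a nitrile and gives 13 ug/mL, so no shift beyond the scatter is expected in this assay. The estimated change is a 1.3-fold lower number from compound 3 to compound 4 (0.10 log units; within the scatter). For compound 4 the expected value is 8 ug/mL, with an estimated range of 3 ug/mL to 18 ug/mL.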

Compound 4, half-maximal inhibitory concentration: 14 ug/mL
Compound 4: the middle estimate sits 1.8-fold (0.24 log units) below what was measured, and the stated range covers the measured number.
By their numbers in this assay, from the lowest: compounds 3, 2, 1 and 4 (each within the scatter of the next).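

In this assay, among these compounds, chloro in place of hydrogen on the aromatic carbon para to a large group gives a 1.4-fold higher number from compound 3 to compound 4 (0.15 log units; within the scatter) and so, tested alone for the first time, stays within the scatter. With that chloro present, amino in place of cyano gives a 1.1-fold higher number from compound 2 to compound 4 (0.03 log units; within the scatter) and also stays within the scatter, so neither single change separates these compounds here. No measurement available here explains these results. On these data alone, whether a bromo or methoxy group at this position, or an acetamide in place of the amino, would move the number beyond the scatter remains open.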